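Series notes: tetrazolyl thiazoles in the TRPM8 channel assay

A few compounds are considered here, and "the series" means these few. Any claim that something is new, unique, unknown or untested is made for them only; others in the source may bear on it.

Measured so far:
compound 1, `CCOC(=O)c1sc(-c2ccccc2)nc1CO` — > 100000 nM
compound 2, `CCn1nnc(-c2sc(-c3ccc(Cl)cc3)nc2O)n1` — 7550 nM
compound 3, `Cn1nnc(-c2sc(-c3cccc(F)c3)nc2O)n1` — 214 nM

In an assay on HEK293 cells for inhibition of transient receptor potential cation channel subfamily M member 8 (Homo sapiens), read by FLIPR, with stated times of 5 min and 3 min (on this read-out higher numbers stand for weaker inhibition and lower numbers for stronger inhibition), compound 1 reaches only a limit, > 100000 nM, and gives no number. Among the two numbers in hand, compound 2 stands at the higher one; compound 3 sits far lower, well beyond the scatter, but the two differ in more than one place, so no single step connects them.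

Compound 4, `CCn1nnc(-c2sc(-c3ccc(O)cc3)nc2O)n1`, is not yet measured. It differs from compound 2 by hydroxy in place of chloro on an aromatic carbon. For the measured compounds named here, no measured pair shows this exchange, so the expectation rests on compound 2 alone. The hydroxy is expected to cost some potency: a step from compound 2 to compound 4 of a 2.0-fold higher number from compound 2 to compound 4 (0.30 log units; within the scatter) is estimated. Compound 4 is expected to give 15000 nM, within 4000 nM to 60000 nM.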

Compound 4, half-maximal inhibitory concentration: 11600 nM
Beside the measured number, compound 4's estimate is 1.3-fold (0.11 log units) above it; the measured number falls inside the stated range.
By their numbers in this assay, from the lowest: compound 3; then compounds 2 and 4 (each within the scatter of the next). At a limit, above all of these: compound 1.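

In this assay the exchange of chloro for hydroxy on the aromatic carbon para to a large group gives a 1.5-fold higher number from compound 2 to compound 4 (0.19 log units; within the scatter). The two groups are therefore not told apart at this position, even with the hydrogen-bond donor and acceptor that hydroxy brings and chloro lacks. Nothing in hand bears on a cause for this step.

From the compounds shown here alone, whether an amine or a carboxylic acid in the same place would give a number beyond the scatter stays open. Also open, going by these compounds, is which of the differences between compound 2 and compound 3 carries the distance between their numbers.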